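Chloro-to-xanthate exchange in a macrocyclic enone series

The compounds below may be only part of what the source reports. "The series", "measured", "known", "first", "only" and "open" are said of these compounds alone.

Measured compounds:
compound 1 `CC(=O)O[C@]1(C)/C=C/C(=O)/C(CO)=C\C[C@](C)(CCC=C(C)C)/C=C/[C@H]1OC(=O)C=C(C)C`: 3150 nM
compound 2 `C=C1/C=C/C(=O)/C(CO)=C\C[C@](C)(CCC=C(C)C)/C=C/[C@H]1OC(=O)C=C(C)C`: 3090 nM
compound 3 `CC(C)=CCC[C@]1(C)/C=C/[C@@H](OC(=O)C=C(C)C)[C@](C)(O)/C=C/C(=O)/C(CCl)=C\C1`: 150 nM

All three have been run in a functional assay on A549 cells (Homo sapiens) for antiproliferative activity, read by MTT assay, with a stated time of 48 h; on this read-out lower numbers stand for stronger inhibition and higher numbers for weaker inhibition. Compound 3 gives 150 nM and stands lowest of the three numbers; compound 2 and compound 1 both lie beyond the scatter above it, and their two values sit within the scatter of each other. Within the data shown here, no pair of measured compounds differs in only one place, so no single step can be read off the measured set.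

Compound 4 `CSC(=S)OC/C1=C/C[C@](C)(CCC=C(C)C)/C=C/[C@@H](OC(=O)C=C(C)C)[C@](C)(O)/C=C/C1=O` has not been measured. It differs from compound 3 by a group of 5 heavy atoms (2 carbon, 1 oxygen, 2 sulfur; no ring) in place of one chlorine atom, on a saturated chain carbon bound to a double-bonded ring carbon. Among the measured compounds shown here, since the only group exchanged is the one that sets compound 3 apart from the weaker compounds 1 and 2, some loss is expected, but the exchange is untested here, so the estimate is wide. The step of a 4.0-fold higher number from compound 3 to compound 4 (0.60 log units; beyond the scatter) is expected to be moderate, toward weaker inhibition. For compound 4 the expected value in this assay is 600 nM, within 150 nM to 2500 nM.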

Compound 4, half-maximal inhibitory concentration: 380 nM
The estimate for compound 4 lay 1.6-fold (0.20 log units) above the measured number, within the range that was stated.
By their numbers in this assay, from the lowest: compound 3; then compound 4; then compounds 2 and 1 (each within the scatter of the next).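

Among these compounds, this is the first change that can be read at a single place: in this assay, putting a group of 5 heavy atoms with no ring in place of one chlorine atom, on a saturated chain carbon bound to a double-bonded ring carbon, gives a 2.5-fold higher number from compound 3 to compound 4 (0.40 log units; beyond the scatter). The step is modest but beyond the scatter, so the position accepts this much larger group at a limited cost, and compound 4 still gives 380 nM. Nothing measured here accounts for the step.

Going by these compounds, how a bromine atom, an azide or an amine would read at this position stays open. Compounds 1 and 2 differ from compound 3 in more than one place, and the share of the chloro group in that gap remains unread.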